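The compounds below may be only part of what the source reports. "The series", "measured", "known", "first", "only" and "open" are said of these compounds alone.

Measured compounds:
compound 1 `Nc1ccccc1NC(=O)CCCNCC(=O)Nc1cccc(Cl)c1`, 22.5%
compound 2 `Nc1ccccc1NC(=O)CCCNCC(=O)Nc1ccc(Cl)cc1`, 75%
compound 3 `Nc1ccccc1NC(=O)CCCNCC(=O)Nc1ccc(Br)cc1`, 68.7%

In a functional assay on the whole organism (Ehrlich cells, Mus musculus) for antiproliferative activity, with a stated time of 24 h, at a dose of 0.2 mmol/kg by the intraperitoneal route (on this read-out lower numbers stand for less inhibition and higher numbers for more inhibition at the one dose given (going by the name of the read-out)), compound 3 gives 68.7%, the second highest of the three numbers; its nearest neighbour is compound 2, and the gap a number 6.3 percentage points lower from compound 2 to compound 3 (within the scatter) lies within the scatter, so the two cannot be ordered. The furthest is compound 1, from which compound 3 differs by a number 46.2 percentage points higher from compound 1 to compound 3 (beyond the scatter).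

The unmeasured compound 4 `Nc1ccccc1NC(=O)CCCNCC(=O)Nc1cccc([N+](=O)[O-])c1` differs from compound 3 in one place: 3-nitrophenyl in place of 4-bromophenyl on an amide-type nitrogen. Going by the values given here, two measured steps bear on this change. Both a number 52.5 percentage points higher from compound 1 to compound 2 (beyond the scatter) and a number 46.2 percentage points higher from compound 1 to compound 3 (beyond the scatter) were large, and both replaced a 3-chlorophenyl with a 4-chlorophenyl or 4-bromophenyl. Among the compounds with values here, compound 4 returns to a 3-nitrophenyl, the only precedent for which is the 3-chlorophenyl of compound 1 with its 22.5%. Nothing here shows what the nitro group itself contributes, so the estimate rests on that one precedent. Compound 4 is therefore expected to fall well below compound 3, with an expected step of a number 38.7 percentage points lower from compound 3 to compound 4 (beyond the scatter). The estimate for compound 4 is 30%, within a range from 10% to 55%.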

Compound 4, a percentage reported as inhibition, in the whole organism at one dose (the size of the read-out at that dose, not a potency): 36%
For compound 4 the middle estimate is 6 percentage points below the measured one; the range from low to high includes it.
By their numbers in this assay, from the lowest: compound 1; then compound 4; then compounds 3 and 2 (each within the scatter of the next).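

In this assay the 3-nitrophenyl on the amide-type nitrogen stays far from both the 4-bromophenyl and the 4-chlorophenyl, with a number 32.7 percentage points lower from compound 3 to compound 4 (beyond the scatter) and with a number 39 percentage points lower from compound 2 to compound 4 (beyond the scatter) as two large steps, so a second group carrying its substituent as in compound 1 also falls well short of compound 2 and compound 3. Going by these compounds alone, the new result also shows for the first time that the substituent itself counts while its place on the ring stays the same: nitro in place of chloro gives a number 13.5 percentage points higher from compound 1 to compound 4 (beyond the scatter) and this step is modest, much smaller than the large steps that separate compound 4 from compound 2 and compound 3. No measurement of any property of these groups stands beside the numbers, and nothing shown accounts for these steps.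

Whether the large loss on going to compound 4 belongs to the nitro group or to its place on the ring remains open, as no compound shown carries a nitro group where compound 3 carries its bromo. On these data alone, how a carboxylic acid or an amine on that phenyl ring would read also remains open.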